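The source may hold more compounds than are shown below. What is called first, only, known or untested is meant among the compounds shown, and "the series" means these compounds.

Measured compounds in the series:
- compound 1 `COc1cc(-c2nn(-c3cccc(NC(=O)c4cccc(C(F)(F)F)c4)c3)cc2-c2ccncc2)ccc1Cl`: 1770 nM
- compound 2 `COc1cc(-c2nn(-c3cccc(NC(=O)Nc4ccc(Cl)c(Cl)c4)c3)cc2-c2ccncc2)ccc1Cl`: 2390 nM
- compound 3 `COc1cc(-c2nn(-c3cccc(NC(=O)Nc4cccc(C(F)(F)F)c4)c3)cc2-c2ccncc2)ccc1Cl`: 2140 nM

In a functional assay on MDA-MB-435 cells (Homo sapiens) for inhibition, read by sulforhodamine B assay, with a stated time of 48 h (on this read-out lower numbers stand for stronger inhibition of growth and higher numbers for weaker inhibition of growth), compound 1 gives 1770 nM, compound 2 gives 2390 nM and compound 3 gives 2140 nM. Compound 3 stands second highest of the three numbers, but its steps to both neighbours are within the scatter: a 1.1-fold lower number from compound 2 to compound 3 (0.05 log units; within the scatter) and a 1.2-fold higher number from compound 1 to compound 3 (0.08 log units; within the scatter). Within the data shown here, the three measured values therefore sit together, and no compound can be called more or less potent than another.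

Compound 4 `COc1cc(-c2nn(-c3cccc(NC(=O)c4ccc(Cl)c(C(F)(F)F)c4)c3)cc2-c2ccncc2)ccc1Cl` differs from compound 3 in one place: 4-chloro-3-(trifluoromethyl)phenyl in place of (3-(trifluoromethyl)phenyl)amino on a carbonyl carbon. Among the measured compounds shown here, two measured steps bear on this. The exchange of the urea-type linkage for the amide between compound 1 and compound 3 gave a 1.2-fold higher number from compound 1 to compound 3 (0.08 log units; within the scatter); the exchange of aryl substituents on the distal ring gave a 1.4-fold higher number from compound 1 to compound 2 (0.13 log units; within the scatter) and a 1.1-fold lower number from compound 2 to compound 3 (0.05 log units; within the scatter), all within the scatter. The change to compound 4 combines both kinds of exchange, so no step beyond the scatter is expected in this assay, in either direction.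

Compound 4 is therefore expected to give 1900 nM, with a range of 900 nM to 4000 nM. The step from compound 3 to compound 4 is estimated as a 1.1-fold lower number from compound 3 to compound 4 (0.05 log units; within the scatter).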

Compound 4, concentration for total growth inhibition: 1740 nM
Compound 4: middle estimate off by 1.1-fold (0.04 log units), on the high side; the range from low to high includes it.
By their numbers in this assay, from the lowest: compounds 4, 1, 3 and 2 (each within the scatter of the next).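

In this assay, chloro in place of hydrogen on an aromatic carbon gives a 1.0-fold lower number from compound 1 to compound 4 (0.01 log units; within the scatter), so this added chlorine yields a step within the scatter. On the carbonyl carbon, the entering 4-chloro-3-(trifluoromethyl)phenyl has no hydrogen-bond donor, whereas the leaving arylamino groups each have one, yet both exchanges stay within the scatter: a 1.2-fold lower number from compound 3 to compound 4 (0.09 log units; within the scatter) and a 1.4-fold lower number from compound 2 to compound 4 (0.14 log units; within the scatter). No measurement is available to explain why these steps remain so small.

With every step among the four compounds within the scatter, the compounds shown do not establish which parts of this position affect growth inhibition. As far as these compounds go, whether a non-aromatic group on the carbonyl carbon, such as a piperidine ring or a longer alkyl chain, would give a step beyond the scatter remains open.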